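Configuration Alone Varied Across Four Isomers

The compounds below may be only part of what the source reports. "The series", "measured", "known", "first", "only" and "open" are said of these compounds alone.

Three compounds that share every atom and bond and differ only in configuration as drawn were tested in a functional assay on SK-OV-3 cells (Homo sapiens) for cytotoxicity, read by sulforhodamine B assay; a higher number here means a weaker inhibitor, a lower number a stronger inhibitor. Compound 1 `O=C(/C=C/c1ccc(O)cc1)O[C@H]1[C@H](O[C@@H]2CCCC[C@H]2O)O[C@H](CO)[C@@H](O)[C@@H]1O` returns only the assay limit, giving > 10000 nM. Compound 2 `O=C(/C=C\c1ccc(O)cc1)O[C@H]1[C@H](O[C@@H]2CCCC[C@H]2O)O[C@H](CO)[C@@H](O)[C@@H]1O` likewise gives no number but the limit > 10000 nM. Compound 3 `O=C(/C=C\c1ccc(O)cc1)O[C@@H]1[C@H](O[C@@H]2CCCC[C@@H]2O)O[C@H](CO)[C@@H](O)[C@H]1O` also stops at the limit, giving > 10000 nM. The steps among them, a step that the two limits leave unreadable from compound 1 to compound 2, a step that the two limits leave unreadable from compound 1 to compound 3 and a step that the two limits leave unreadable from compound 2 to compound 3, cannot be read because the limit of > 10000 nM in this assay, at which 3 of the 3 values shown sit, applies to every value shown. Compound 4 `O=C(/C=C/c1ccc(O)cc1)O[C@H]1[C@H](O[C@H]2CCCC[C@H]2O)O[C@H](CO)[C@@H](O)[C@@H]1O` is not yet measured; it differs from compound 3 by the two compounds have the same atoms and bonds and differ only in configuration as drawn: 5 of 8 stereo elements differ; a stereocentre at a saturated ring carbon is drawn S in compound 3 and R in compound 4; a stereocentre at a saturated ring carbon is drawn R in compound 3 and S in compound 4; a stereocentre at a saturated ring carbon is drawn S in compound 3 and R in compound 4; a stereocentre at a saturated ring carbon is drawn R in compound 3 and S in compound 4. Among the compounds with values here, no measured step shows how a change of configuration moves this assay, so the expected step that the limit leaves unreadable from compound 3 to compound 4 is none beyond the scatter. Compound 4 is therefore estimated at 20000 nM, with a range from 8000 nM to 60000 nM.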

Compound 4, half-maximal inhibitory concentration: > 10000 nM
Compound 4: only a limit was reported; the forecaster's own chance of this, stated with the estimate: 85%; the middle value does not contradict the limit.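

In this assay compound 4 gives > 10000 nM, again a limit and not a number, so its steps from compound 1, compound 2 and compound 3 cannot be read: the limit of > 10000 nM in this assay, at which 4 of the 4 values shown sit. As far as these compounds go, whether configuration moves this read-out at all in these four compounds stays open.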